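The compounds below may be only part of what the source reports. "The series", "measured", "known", "first", "only" and "open" are said of these compounds alone.

Of the compounds shown here, three built on the shared core have been tested in a functional assay on HCT-116 cells (Homo sapiens) for inhibition, read by sulforhodamine B assay, with a stated time of 48 h; on this read-out higher numbers stand for lower toxicity in this test and lower numbers for higher toxicity in this test. Compound 1 `CCOC(=O)[C@H](CCC(=O)O)NC(=O)c1ccc(CNc2nc3cc(N)cc(N)c3nc2-c2ccccc2)cc1` gives < 100000 nM, and this value is a limit of the assay rather than a number. Compound 2 `COc1cc(CNc2nc3cc(N)cc(N)c3nc2-c2ccccc2)cc(OC)c1OC` gives 37200 nM in this assay. Compound 3 `COc1ccc(Sc2nc3cc(N)cc(N)c3nc2-c2ccccc2)cc1` gives < 100000 nM in this assay, which again is a limit of the assay and not a number. Compound 3 thus stands at the edge of what this assay reports: among the values shown there is the limit of < 100000 nM in this assay, at which 2 of the 3 values shown sit, and only compound 2 carries an actual number. For the measured compounds named here, no two of these three compounds differ in a single place, so no measured step between them can be drawn.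

Compound 4 `Nc1cc(N)c2nc(-c3ccccc3)c(Sc3ccc(F)cc3)nc2c1` has not yet been measured. It differs from compound 3 by fluoro in place of methoxy on an aromatic carbon, para to a large group. Going by the values given here, no measured step is available to guide this change, and compound 3 itself sits at a limit. The step from compound 3 to compound 4 is expected to be a step that the limit leaves unreadable from compound 3 to compound 4, none beyond the scatter in this assay. Compound 4 is accordingly estimated to give 60000 nM in this assay, with a range from 15000 nM to 150000 nM, and a fair chance that only a limit is reported once more.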

Compound 4, concentration lethal to 50% of the cells: 55000 nM
Compound 4: the middle estimate sits 1.1-fold (0.04 log units) above what was measured, within the range that was stated.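

No step can be read from compound 3 to compound 4 in this assay, for compound 3 carries only a limit of the assay and not a number: the limit of < 100000 nM in this assay, at which 2 of the 4 values shown sit.

The compounds shown leave open what fluoro in place of methoxy on an aromatic carbon does in this assay when both partners carry an actual number.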